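The source may report more compounds than this note shows. Statements on the series, on what has been measured and on what is new or still open speak of the compounds shown alone.

The measured compounds, with their values in a functional assay on A549 cells (Homo sapiens) for antiproliferative activity, read by MTT assay, with a stated time of 48 h; on this read-out lower numbers stand for stronger inhibition and higher numbers for weaker inhibition:
Compound 1, `O=C(/C=C/c1ccccc1Br)Nc1ccc2ncnc(Nc3cccc(Cl)c3)c2c1`, gives 5.63 ug/mL.
Compound 2, `Cc1ccc(/C=C/C(=O)Nc2ccc3ncnc(Nc4cccc(Cl)c4)c3c2)cc1`, gives 6.03 ug/mL.
Compound 3, `O=C(/C=C/c1cccc2ccccc12)Nc1ccc2ncnc(Nc3cccc(Cl)c3)c2c1`, gives 1.49 ug/mL.

All three share the same core and differ only in the aryl group on the double-bonded chain carbon. Compound 3 stands lowest of the three numbers, and its lead over the other two is beyond the usual scatter: a 3.8-fold lower number from compound 1 to compound 3 (0.58 log units; beyond the scatter) and a 4.0-fold lower number from compound 2 to compound 3 (0.61 log units; beyond the scatter). The two phenyl-bearing compounds, by contrast, sit close together: a 1.1-fold higher number from compound 1 to compound 2 (0.03 log units; within the scatter).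

Compound 4, `O=C(/C=C/c1ccc([N+](=O)[O-])cc1)Nc1ccc2ncnc(Nc3cccc(Cl)c3)c2c1`, has not yet been measured in this assay. It differs from compound 3 in one place: 4-nitrophenyl in place of naphthalen-1-yl on a double-bonded chain carbon bound to a double-bonded chain carbon. The change returns to a single six-membered ring of carbon, the pattern of compound 1 and compound 2. The two steps from those compounds to compound 3 therefore bear on it; both were modest and ran downward, so going the opposite way the number is expected to rise by a similar, modest amount. Among the compounds with values here, no measured step shows what a nitro group does here, so the estimate rests on the ring count alone. Compound 4 is expected to give 5 ug/mL, in a range from 2 ug/mL to 12 ug/mL, an expected step of a 3.4-fold higher number from compound 3 to compound 4 (0.53 log units; beyond the scatter).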

Compound 4, half-maximal inhibitory concentration: 5.26 ug/mL
Estimate against measurement, compound 4: 1.1-fold (0.02 log units) below; low and high end bracket the measured number.
By their numbers in this assay, from the lowest: compound 3; then compounds 4, 1 and 2 (each within the scatter of the next).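

In this assay, the 4-nitrophenyl group at this position falls in with the other single-ring groups and not with the naphthalen-1-yl of compound 3, as shown by a 3.5-fold higher number from compound 3 to compound 4 (0.55 log units; beyond the scatter) for the swap of the two-ring group for the nitro-bearing ring. Nitro and methyl on the aromatic carbon cannot be told apart, with a 1.1-fold lower number from compound 2 to compound 4 (0.06 log units; within the scatter) in this comparison, and the same holds for the 4-nitrophenyl and 2-bromophenyl groups, with a 1.1-fold lower number from compound 1 to compound 4 (0.03 log units; within the scatter) here, so three differently substituted phenyl groups now sit together and only the two-ring group stands apart. No data are available to explain why compound 3 gives the lower number.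

On these data alone, that separation rests on compound 3 alone, so it remains open whether another group with two aromatic rings, such as naphthalen-2-yl, would also give a low number. Also open, as far as these compounds go, is what an amine or a carboxylic acid in place of the nitro would do, and whether a saturated cyclohexyl group in place of the aromatic ring would keep the number of the single-ring compounds.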